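The source may report more compounds than this note shows. Statements on the series, on what has been measured and on what is new or still open speak of the compounds shown alone.

Of the compounds shown here, three that share one core have been tested in a functional assay on HCT-116 cells (Homo sapiens) for inhibition, read by MTT assay, with a stated time of 72 h; on this read-out lower numbers stand for stronger inhibition and higher numbers for weaker inhibition. Compound 1 `COc1cc(Oc2cccc(Nc3ccccc3)c2)cc(OC)c1CNCCNC(C)=O` gives 18200 nM in this assay. Compound 2 `COc1cc(Oc2cccc(Nc3ccccc3)c2)cc(OC)c1CNCc1ccc(C)cc1` gives 13800 nM, a change of a 1.3-fold lower number from compound 1 to compound 2 (0.12 log units; within the scatter). Compound 3 `COc1cc(Oc2cccc(Nc3ccccc3)c2)cc(OC)c1CN[C@H](C)c1ccccc1` reaches only the limit of this assay, > 20000 nM, so its value is a boundary rather than a number, as shown by the limit of > 20000 nM in this assay, at which 1 of the 3 values shown sits. Compound 3 therefore stands at the edge of what this assay can report: the steps of an at least 1.0-fold higher number from compound 1 to compound 3 (0.04 log units; that floor lies within the scatter) and an at least 1.4-fold higher number from compound 2 to compound 3 (0.16 log units; that floor lies within the scatter) are floors whose size cannot be set beyond the scatter.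

Compound 4 `COc1cc(Oc2cccc(Nc3ccccc3)c2)cc(OC)c1CNCc1ccc(Cl)cc1` carries 4-chlorobenzyl in place of 1-phenylethyl on an amine nitrogen. For the measured compounds named here, the step that bears most on it is the one between compound 2 and compound 3, where a 4-methylbenzyl group gave a number and the 1-phenylethyl group gave only a limit; returning to a benzyl bearing a 4-chloro group is expected to land near compound 2, an expected step of an at least 1.2-fold lower number from compound 3 to compound 4 (0.09 log units; that floor lies within the scatter). Compound 4 is thus estimated at 16000 nM, with a range from 7000 nM to 40000 nM.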

Compound 4, half-maximal inhibitory concentration: 3310 nM
For compound 4 the middle estimate is 4.8-fold (0.68 log units) above the measured one, outside the stated range (below it).
By their numbers in this assay, from the lowest: compound 4; then compounds 2 and 1 (each within the scatter of the next). At a limit, above all of these: compound 3.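

For the compounds shown here, on the amine nitrogen of the shared core, no step among the earlier compounds in this assay lay beyond the scatter, so they did not show that a change here could matter. Going by these compounds alone, that now appears in the step of a 4.2-fold lower number from compound 2 to compound 4 (0.62 log units; beyond the scatter), where the only change is chloro in place of methyl on an aromatic carbon, and the 4-chlorobenzyl group also separates from the acetamide-bearing chain, with a 5.5-fold lower number from compound 1 to compound 4 (0.74 log units; beyond the scatter). Against the 1-phenylethyl group, the step of an at least 6.0-fold lower number from compound 3 to compound 4 (0.78 log units; beyond the scatter) is only a floor, and compound 3 itself is a limit: the limit of > 20000 nM in this assay, at which 1 of the 4 values shown sits.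

Going by these compounds, whether a fluoro, bromo or methoxy group on the benzyl group would match the chloro group remains open. Also open, on these data alone, is whether a 1-(4-chlorophenyl)ethyl group would keep the number of compound 4 or return to a limit like compound 3.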